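Cytotoxicity on liver cells: swapping the amide aryl group

The source may hold more compounds than are shown below. What is called first, only, known or untested is meant among the compounds shown, and "the series" means these compounds.

Measured compounds:
compound 1, `CCCCS(=O)(=O)Oc1ccc(/C=C/C(=O)Nc2cccc(C)c2)cc1OC`: 33600 nM
compound 2, `CCCCOC(=O)/C=C/c1ccc(OS(=O)(=O)c2ccc(Cl)cc2)c(OC)c1`: 14000 nM
compound 3, `COc1cc(/C=C/C(=O)Nc2ccc(I)cc2)ccc1OS(=O)(=O)c1ccc(Cl)cc1`: 39400 nM

All three were tested in a toxicity assay on L02 cells (Homo sapiens) for cytotoxicity, read by MTT assay, with a stated time of 24 h; a higher number here means that more compound is tolerated, a lower number that less compound is tolerated. Compound 3 gives 39400 nM, a number that stands beyond the scatter above compound 2 but within the scatter of compound 1. Among the measured compounds shown here, the only single-point step among the measured compounds is a 2.8-fold higher number from compound 2 to compound 3 (0.45 log units; beyond the scatter), which concerns the group on the carbonyl carbon, not the aryl group on the amide nitrogen.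

Compound 4, `COc1cc(/C=C/C(=O)Nc2cccc(C)c2)ccc1OS(=O)(=O)c1ccc(Cl)cc1`, differs from compound 3 in one place: 3-methylphenyl in place of 4-iodophenyl on an amide-type nitrogen. For the measured compounds named here, no measured step covers exactly this change. The closest information comes from compound 1, which carries the same 3-methylphenyl group on the amide nitrogen and gives 33600 nM, a value within the scatter of compound 3, although compound 1 also differs from compound 3 in the group on the sulfonyl.

On that basis compound 4 is expected to show no step beyond the scatter, with a 1.1-fold lower number from compound 3 to compound 4 (0.05 log units; within the scatter). In this assay compound 4 is therefore estimated at 35000 nM, within a range from 15000 nM to 80000 nM.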

Compound 4, half-maximal cytotoxic concentration: 73500 nM
For compound 4 the middle estimate is 2.1-fold (0.32 log units) below the measured one; the measured number falls inside the stated range.
By their numbers in this assay, from the lowest: compound 2; then compounds 1, 3 and 4 (each within the scatter of the next, the first and the last beyond it).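

In this assay, the change from 4-iodophenyl to 3-methylphenyl on the amide-type nitrogen gives a 1.9-fold higher number from compound 3 to compound 4 (0.27 log units; within the scatter), so this pair does not separate the two aryl groups at this position. Among the compounds shown here, the group on the sulfonyl sulfur, which no earlier step covered, does separate a pair: 4-chlorophenyl in place of butyl gives a 2.2-fold higher number from compound 1 to compound 4 (0.34 log units; beyond the scatter), while replacing the butoxy group on the carbonyl carbon with the (3-methylphenyl)amino group gives a 5.3-fold higher number from compound 2 to compound 4 (0.72 log units; beyond the scatter), a second step beyond the scatter at the carbonyl carbon alongside a 2.8-fold higher number from compound 2 to compound 3 (0.45 log units; beyond the scatter). Nothing available bears on the reason for any of these steps.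

The compounds shown leave open whether the step at the sulfonyl sulfur also holds with 4-iodophenyl on the amide-type nitrogen, since it rests on a single pair carrying 3-methylphenyl. They also leave open how this assay responds to a benzyl group or a cyclohexyl ring on that nitrogen, or to a longer chain on the sulfonyl sulfur.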